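The source may report more compounds than this note shows. Statements on the series, on what has been measured and on what is new or still open speak of the compounds shown alone.

Compounds measured so far in a functional assay on HT-29 cells (Homo sapiens) for cytotoxicity, read by MTT assay, with a stated time of 24 h; a lower number here means a stronger inhibitor, a higher number a weaker inhibitor: compound 1 `O=Cc1cc(Br)ccc1OCc1cn(CCCOc2ccc3ccc(=O)oc3c2)nn1` gives 7470 nM; compound 2 `O=Cc1cc([N+](=O)[O-])ccc1OCc1cn(CCCOc2ccc3ccc(=O)oc3c2)nn1` gives 53600 nM; compound 3 `NS(=O)(=O)c1ccc(C/N=C/c2cc(Br)ccc2OCc2cn(CCCOc3ccc4ccc(=O)oc4c3)nn2)cc1` gives 17700 nM.

Compound 1 and compound 2 differ in one place, (nitro in place of bromo on an aromatic carbon), and that change gave a 7.2-fold higher number from compound 1 to compound 2 (0.86 log units; beyond the scatter). Compound 4 `NS(=O)(=O)c1ccc(C/N=C/c2cc([N+](=O)[O-])ccc2OCc2cn(CCCOc3ccc4ccc(=O)oc4c3)nn2)cc1` is not yet measured; it differs from compound 3 by nitro in place of bromo on an aromatic carbon. This is the same kind of change, though its surroundings are not identical: in compound 1 the site is meta to a formyl group, in compound 3 it is meta to a large group. How the core of compound 3 differs from the core of compound 1 is not broken down here. For compound 4 a step of about a 5.6-fold higher number from compound 3 to compound 4 (0.75 log units; beyond the scatter) is expected, because the same kind of change gave a 7.2-fold higher number from compound 1 to compound 2 (0.86 log units; beyond the scatter). Compound 4 is therefore estimated at 100000 nM, within 40000 nM to 250000 nM.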

Compound 4, half-maximal inhibitory concentration: 117000 nM
Beside the measured number, compound 4's estimate is 1.2-fold (0.07 log units) below it; low and high end bracket the measured number.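

In this assay, nitro in place of bromo gave a 6.6-fold higher number from compound 3 to compound 4 (0.82 log units; beyond the scatter), and this step can be set beside the same change on the other core: the same change on two cores in this assay, a 7.2-fold higher number (0.86 log units; beyond the scatter) from compound 1 to compound 2 and a 6.6-fold higher number (0.82 log units; beyond the scatter) from compound 3 to compound 4, 1.1-fold (0.04 log units) apart, within the scatter of two such steps. On these two cores, then, the change carried over at much the same size, so the earlier step was a fair guide here. For the compounds shown here, still, these are only two pairs in one cell assay, so this does not show that the step would hold on other cores, nor why nitro gives the higher number.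

The compounds shown leave open how other groups at this site would behave, such as an amine or a carboxylic acid in place of bromo. They also leave open whether the step would stay the same with a longer chain in the molecule.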